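Quinolin-4-yl in Place of Furan-2-yl on Compound 2

The source may report more compounds than this note shows. Statements on the series, on what has been measured and on what is new or still open speak of the compounds shown alone.

In a toxicity assay on MT4 cells (Homo sapiens) for cytotoxicity, read by MTT assay, with a stated time of 5 days (on this read-out lower numbers stand for higher toxicity in this test and higher numbers for lower toxicity in this test), compound 1 `Cc1cnc(Nc2ccc(C#N)cc2)nc1Nc1c(F)cc(-c2cncnc2)cc1F` gives 900 nM and compound 2 `Cc1cc(-c2ccco2)cc(C)c1Nc1ccnc(Nc2ccc(C#N)cc2)n1` gives 1700 nM. For the measured compounds named here, these two values lie within the usual scatter of each other, so compound 2 stands level with the only other measured compound. Going by the values given here, the two compounds differ in more than one place, which leaves no measured single-place step to serve as a guide.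

Compound 3 `Cc1cc(-c2ccnc3ccccc23)cc(C)c1Nc1ccnc(Nc2ccc(C#N)cc2)n1` keeps the rest of compound 2 and carries quinolin-4-yl in place of furan-2-yl on an aromatic carbon, meta to two methyl groups (quinolin-4-yl in place of furan-2-yl on an aromatic carbon). The data show nothing directly about this swap in this assay. Although it differs from compound 2 in more than one place, compound 1 still gives 900 nM, so only a modest step toward a higher number is expected, not far beyond the scatter. The estimated change is a 1.6-fold higher number from compound 2 to compound 3 (0.22 log units; within the scatter). For compound 3 the expected value is 2800 nM, with an estimated range from 800 nM to 10000 nM.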

Compound 3, half-maximal cytotoxic concentration: 3500 nM
For compound 3 the middle estimate is 1.3-fold (0.10 log units) below the measured one, within the range that was stated.
By their numbers in this assay, from the lowest: compounds 1 and 2 (each within the scatter of the next); then compound 3.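

In this assay, the aromatic carbon meta to two methyl groups and para to a large group now gives the first single-place step, and it shows that the group held there can move the number: quinolin-4-yl in place of furan-2-yl gives a 2.1-fold higher number from compound 2 to compound 3 (0.31 log units; beyond the scatter), modest in size. The direction is toward lower toxicity in this test, and it comes with a group of 10 heavy atoms replacing one of 5, while the count of hydrogen-bond acceptors and the absence of net charge stay the same. No measurement given here accounts for the step.

A single step cannot separate the effect of the added six-membered aromatic ring from that of exchanging the oxygen-bearing five-membered ring for a nitrogen-bearing six-membered one. As far as these compounds go, it also remains open how a small group such as an amine or a carboxylic acid would read at this position, and whether quinolin-4-yl would move the number in the same direction on the core of compound 1.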